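Dihydropyridine Analogues Tested on Guinea Pig Muscle

The source may hold more compounds than are shown below. What is called first, only, known or untested is meant among the compounds shown, and "the series" means these compounds.

The series shares one core. Compound 1 `COC(=O)C1=C(C)N=C(C)/C(=C(\O)OC)C1c1cc(OC)c(OC)cc1OC` gives 1000000 nM in a functional assay (muscle tissue) with Cavia porcellus as the target (a lower number here means that less compound is needed, a higher number that more compound is needed for the effect), the highest number of the three. Compound 2 `COC(=O)C1=C(C)N=C(C)/C(=C(\O)OC)C1c1cc([N+](=O)[O-])ccc1Cl` gives 30.2 nM in this assay. Compound 3 `CCc1ccccc1C1C(C(=O)OC)=C(C)N=C(C)/C1=C(\O)OC` stands lowest with 6.46 nM, a gap to compound 2 beyond the scatter and a very wide gap to compound 1.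

Compound 4 `COC(=O)C1=C(C)N=C(C)/C(=C(\O)OC)C1c1cccc(F)c1` has not yet been measured. It differs from compound 3 in one place: 3-fluorophenyl in place of 2-ethylphenyl on a saturated ring carbon. Nothing in the measured set isolates this exchange, so the expectation rests on the whole series. Compound 4 is expected to remain among the lower numbers, with a modest upward step from compound 3 estimated at a 2.3-fold higher number from compound 3 to compound 4 (0.37 log units; beyond the scatter). The estimate for compound 4 is 15 nM, with a range from 3 nM to 80 nM.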

Compound 4, half-maximal effective concentration: 20.9 nM
Compound 4: the middle estimate sits 1.4-fold (0.14 log units) below what was measured; measured number inside the range.
By their numbers in this assay, from the lowest: compound 3; then compounds 4 and 2 (each within the scatter of the next); then compound 1.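

Going by these compounds alone, the exchange of 2-ethylphenyl for 3-fluorophenyl on the saturated ring carbon gives a 3.2-fold higher number from compound 3 to compound 4 (0.51 log units; beyond the scatter) in this assay and is the first change that can be read in one place. It shows that the number at this position moves only modestly when the ethyl group gives way to fluorine and the group's place on the phenyl ring changes too. No measurement at hand explains this step. Within the data shown here, the single step cannot separate the identity of the group from its place on the phenyl ring. As far as these compounds go, how a plain phenyl group or a phenyl ring carrying a carboxylic acid would stand remains open.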